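Triazole side-chain variation on the shared core

This account rests on a few compounds, and the source may have more. Where it says the series, first, only, none or still open, it means among the compounds named here.

Compound 1 `O=C1O[C@H]([C@@H](O)Cn2cc(CNS(=O)(=O)c3ccc(Cl)cc3)nn2)C(OCc2ccccc2)=C1OCc1ccccc1` gives 2870 nM in a functional assay on A549 cells (Homo sapiens) for antiproliferative activity, read by MTT assay, with a stated time of 72 h; on this read-out higher numbers stand for weaker inhibition and lower numbers for stronger inhibition.
Compound 2 `O=C1O[C@H]([C@@H](O)Cn2cc(CCCCl)nn2)C(OCc2ccccc2)=C1OCc1ccccc1` gives 29000 nM in this assay.
Compound 3 `O=C1O[C@H]([C@@H](O)Cn2cc(CCO)nn2)C(OCc2ccccc2)=C1OCc1ccccc1` reaches only the assay limit, > 100000 nM in this assay.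

Compound 3 stands at the weak end of the three: its value is a limit and not a number, a point recorded as the limit of > 100000 nM in this assay, at which 1 of the 3 values shown sits. Within the data shown here, the steps of an at least 34-fold higher number from compound 1 to compound 3 (1.54 log units; beyond the scatter) and an at least 3.4-fold higher number from compound 2 to compound 3 (0.53 log units; beyond the scatter) both run toward it, so the hydroxymethyl-bearing side chain is the weakest of the three on this core, with no compound going against that.

Compound 4 `O=C1O[C@H]([C@@H](O)Cn2cc(CNS(=O)(=O)c3ccc(Cl)cc3F)nn2)C(OCc2ccccc2)=C1OCc1ccccc1` differs from compound 3 by ((4-chloro-2-fluorophenyl)sulfonyl)amino in place of hydroxymethyl on a saturated chain carbon bound to an aromatic carbon. The step that bears on it most directly is an at least 34-fold higher number from compound 1 to compound 3 (1.54 log units; beyond the scatter), which is the same exchange in reverse except for the added fluorine on the ring. Reversing that step would be expected to bring a large decrease in this assay, landing near compound 1; nothing among the measured compounds speaks to the fluorine itself. Compound 4 is therefore estimated at 2500 nM (range 800 nM to 9000 nM), a step of an at least 40-fold lower number from compound 3 to compound 4 (1.60 log units; beyond the scatter).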

Compound 4, half-maximal inhibitory concentration: 39100 nM
Compound 4: the middle estimate sits 16-fold (1.19 log units) below what was measured; measured number outside the range, above it.
By their numbers in this assay, from the lowest: compound 1; then compounds 2 and 4 (each within the scatter of the next). At a limit, above all of these: compound 3.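

In this assay, fluoro in place of hydrogen on an aromatic carbon, a single change, gives a 14-fold higher number from compound 1 to compound 4 (1.13 log units; beyond the scatter) and removes much of the advantage that the ((4-chlorophenyl)sulfonyl)amino group of compound 1 held over the other side chains. The ((4-chloro-2-fluorophenyl)sulfonyl)amino group still improves on hydroxymethyl, with an at least 2.5-fold lower number from compound 3 to compound 4 (0.40 log units; beyond the scatter) on the record, but a 1.3-fold higher number from compound 2 to compound 4 (0.13 log units; within the scatter) leaves it level with 2-chloroethyl, so the sulfonylamino link alone does not secure the activity of compound 1. Compound 3 remains a limit and not a number: the limit of > 100000 nM in this assay, at which 1 of the 4 values shown sits.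

The compounds shown do not tell whether a methoxy group or a bromine at the same ring carbon would cost as much as fluoro. Nor do they show how a primary amine or a carboxylic acid would behave on the saturated chain carbon bound to the aromatic carbon.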